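A few compounds are considered here, and "the series" means these few. Any claim that something is new, unique, unknown or untested is made for them only; others in the source may bear on it.

Of the compounds shown here, two have numbers so far in a functional assay on MDA-MB-231 cells (Homo sapiens) for cytotoxicity, read by MTT assay, with a stated time of 72 h; on this read-out higher numbers stand for weaker inhibition and lower numbers for stronger inhibition. Compound 1 (`CC1CCN(Cc2ccc3nc(NC(=O)N/N=C/c4cn(Cc5ccc(Cl)cc5Cl)c5ccccc45)sc3c2)CC1`) gives 3140 nM, and compound 2 (`CN(C)Cc1ccc2nc(NC(=O)N/N=C/c3cn(Cc4ccccc4)c4ccccc34)sc2c1`) gives 1340 nM. Compound 2 therefore holds the lower of the two numbers, and its gap to compound 1 lies beyond the usual scatter. Compound 3 (`CC1CCN(Cc2ccc3nc(NC(=O)N/N=C/c4cn(Cc5ccccc5)c5ccccc45)sc3c2)CC1`), not yet measured, departs from compound 2 in one place: 4-methylpiperidin-1-yl in place of dimethylamino on a saturated chain carbon bound to an aromatic carbon. In words, 4-methylpiperidin-1-yl stands in place of dimethylamino on a saturated chain carbon bound to an aromatic carbon. Going by the values given here, no measured pair isolates this change, since compound 1 and compound 2 differ in more than one place. Among the compounds with values here, the only hint is that compound 1, which also carries 4-methylpiperidin-1-yl, gives 3140 nM. A small rise in the number in this assay is therefore expected, one that stays within the scatter. The estimated size of this change is a 1.3-fold higher number from compound 2 to compound 3 (0.13 log units; within the scatter). For compound 3 the expected value is 1800 nM, with an estimated range from 750 nM to 3800 nM.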

Compound 3, half-maximal inhibitory concentration: 2850 nM
For compound 3 the middle estimate is 1.6-fold (0.20 log units) below the measured one; measured number inside the range.
By their numbers in this assay, from the lowest: compound 2; then compounds 3 and 1 (each within the scatter of the next).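

In this assay, the exchange of dimethylamino for 4-methylpiperidin-1-yl on a saturated chain carbon bound to an aromatic carbon now has a measured step of its own, a 2.1-fold higher number from compound 2 to compound 3 (0.33 log units; beyond the scatter), a modest change that the earlier pair could not isolate. The second pair isolates the other place: phenyl in place of 2,4-dichlorophenyl on a saturated chain carbon bound to an aromatic nitrogen gives a 1.1-fold lower number from compound 1 to compound 3 (0.04 log units; within the scatter), so with 4-methylpiperidin-1-yl present, this exchange produces no change that can be read beyond the scatter. Taken together, these two steps show that, among the three compounds, the only single-place change beyond the scatter is the one at the amine.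

The compounds shown leave open whether the amine step would hold with 2,4-dichlorophenyl in place of phenyl, and how a morpholine ring or a piperidine ring without the methyl group would read on the same chain carbon. Nothing available explains the size of either step.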